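The compounds below may be only part of what the source reports. "The series", "measured", "known", "first", "only" and "open" are said of these compounds alone.

Measured in a functional assay on LOX IMVI cells (Homo sapiens) for cytotoxicity, read by MTT assay, with a stated time of 24 h; a lower number here means a stronger inhibitor, a higher number a weaker inhibitor:
Compound 1 `COc1cc(-c2nc(-c3ccccc3)[nH]c2-c2ccnc(NCCCNS(=O)(=O)c3ccccc3)n2)ccc1Cl`: 7470 nM
Compound 2 `COc1cc(-c2nc(-c3ccccc3)[nH]c2-c2ccnc(NCCCNS(=O)(=O)c3ccc(F)cc3)n2)ccc1Cl`: 4530 nM
Compound 3 `O=S(=O)(NCCCNc1nccc(-c2[nH]c(-c3ccccc3)nc2-c2ccc(F)c(O)c2)n1)c1ccccc1`: 9580 nM

In this assay, compound 3 gives 9580 nM. Its distance from the first entry is small: a 1.3-fold higher number from compound 1 to compound 3 (0.11 log units; within the scatter). Its number is higher than that of compound 2, which gives 4530 nM.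

Compound 4 `O=S(=O)(NCCCNc1nccc(-c2[nH]c(-c3ccccc3)nc2-c2ccc(F)c(O)c2)n1)c1ccc(F)cc1` keeps everything in compound 3 except that phenylsulfonyl becomes (4-fluorophenyl)sulfonyl: fluoro in place of hydrogen on an aromatic carbon. The same replacement of hydrogen by fluoro has been measured once, with 4-chloro-3-methoxyphenyl in place of 4-fluoro-3-hydroxyphenyl: a 1.6-fold lower number from compound 1 to compound 2 (0.22 log units; within the scatter). That single step stays within the scatter, so it is only a weak guide. The other measured step, a 1.3-fold higher number from compound 1 to compound 3 (0.11 log units; within the scatter), concerns a different part of the molecule and says little about this change.

A small drop is therefore expected, quite possibly none beyond the scatter. The estimated step is a 1.7-fold lower number from compound 3 to compound 4 (0.22 log units; within the scatter). Compound 4 is expected at about 5800 nM, with an estimated range of 3400 nM to 9800 nM.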

Compound 4, half-maximal inhibitory concentration: 19200 nM
Beside the measured number, compound 4's estimate is 3.3-fold (0.52 log units) below it; the measured number lies above the stated range.
By their numbers in this assay, from the lowest: compounds 2, 1, 3 and 4 (each within the scatter of the next, the first and the last beyond it).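

On the core of compound 3, putting fluoro on the phenylsulfonyl ring gives a 2.0-fold higher number from compound 3 to compound 4 (0.30 log units; within the scatter), so the small drop seen on the core of compound 1 does not carry over, and the two steps point in opposite directions: the same change on two cores in this assay, a 1.6-fold lower number (0.22 log units; within the scatter) from compound 1 to compound 2 and a 2.0-fold higher number (0.30 log units; within the scatter) from compound 3 to compound 4, 3.3-fold (0.52 log units) apart, beyond the scatter of two such steps

The other change behaves in the same way, since with the (4-fluorophenyl)sulfonyl group in place, 4-fluoro-3-hydroxyphenyl for 4-chloro-3-methoxyphenyl gives a 4.2-fold higher number from compound 2 to compound 4 (0.63 log units; beyond the scatter): the same change on two cores in this assay, a 1.3-fold higher number (0.11 log units; within the scatter) from compound 1 to compound 3 and a 4.2-fold higher number (0.63 log units; beyond the scatter) from compound 2 to compound 4, 3.3-fold (0.52 log units) apart, beyond the scatter of two such steps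

Across these four compounds, then, the effect of fluoro at this position depends on the group at the other end of the molecule, and the two changes cannot simply be added.

Only hydrogen and fluoro are shown on this ring, so it remains open whether a chloro, a methoxy or an amine there would show the same dependence. Each core also offers just one such pair, which leaves the generality of this pattern unknown.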